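From Propyl to Butyl on the Diethylamino Chain

The compounds below may be only part of what the source reports. "The series", "measured", "known", "first", "only" and "open" are said of these compounds alone.

In a functional assay on HL60/MX2 cells (Homo sapiens) for antiproliferative activity, read by MTT assay, with a stated time of 48 h (on this read-out higher numbers stand for weaker inhibition and lower numbers for stronger inhibition), compound 1 `CCCn1c(N)c(-c2nc3ccccc3[nH]2)c2nc(C#N)c(C#N)nc21` is reported only as a limit, > 50000 nM. Among the measured compounds shown here, compound 2 `CCN(CC)CCCn1c(N)c(-c2nc3ccccc3[nH]2)c2nc(C#N)c(C#N)nc21` gives 1820 nM, so it holds the only exact number so far. For the measured compounds named here, the one measured step is large: an at least 27-fold lower number from compound 1 to compound 2 (1.43 log units; beyond the scatter). It comes from diethylamino in place of hydrogen on a saturated chain carbon, and it says nothing directly about chain length.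

Compound 3 `CCN(CC)CCCCn1c(N)c(-c2nc3ccccc3[nH]2)c2nc(C#N)c(C#N)nc21` differs from compound 2 by (diethylamino)methyl in place of diethylamino on a saturated chain carbon, three bonds along the chain from an aromatic nitrogen, which reads as 3-(diethylamino)propyl to 4-(diethylamino)butyl. Compound 3 keeps the diethylamino group, so the large gain seen in an at least 27-fold lower number from compound 1 to compound 2 (1.43 log units; beyond the scatter) is expected to persist. Going by the values given here, no measured step tests this lengthening, so no step beyond the scatter is expected in this assay, and neither direction is favoured. The expected change is a 1.0-fold lower number from compound 2 to compound 3 (0.00 log units; within the scatter). Compound 3 is estimated at 1800 nM, with an expected range of 600 nM to 6000 nM.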

Compound 3, half-maximal inhibitory concentration: 1550 nM
Beside the measured number, compound 3's estimate is 1.2-fold (0.06 log units) above it, within the range that was stated.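

In this assay, the change from 3-(diethylamino)propyl to 4-(diethylamino)butyl gives a 1.2-fold lower number from compound 2 to compound 3 (0.07 log units; within the scatter), so at this position the two chain lengths cannot be told apart. The large gain from placing diethylamino on the chain also holds for the longer chain, with an at least 32-fold lower number from compound 1 to compound 3 (1.50 log units; beyond the scatter). Compound 1 remains a limit, so the full size of that gain cannot be read: the limit of > 50000 nM in this assay, at which 1 of the 3 values shown sits.

The compounds shown leave open whether a shorter 2-(diethylamino)ethyl chain or a longer 5-(diethylamino)pentyl chain would stay at this level. They also leave open whether another amine at the chain end, such as morpholine or dimethylamino, would serve in the same way as diethylamino.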